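Second methyl on the amide nitrogen of compound 2

A few compounds are considered here, and "the series" means these few. Any claim that something is new, unique, unknown or untested is made for them only; others in the source may bear on it.

Compound 2 `CNC(=O)c1sc2ncccc2c1N` carries a methylcarbamoyl group on the shared core. In an assay on isolated protein for inhibition of LIM domain kinase 1 (Homo sapiens), read by Kinase-Glo, with a stated time of 60 min (on this read-out lower numbers stand for stronger inhibition and higher numbers for weaker inhibition), compound 2 gives > 100000 nM, which is a limit of the assay and not a number. Compound 1 `NNC(=O)c1sc2ncccc2c1N` has an amino group on that amide-type nitrogen instead; in this assay compound 1 gives > 100000 nM, again a limit. Compound 3 `Nc1c(C(=O)O)sc2ccccc12` gives > 100000 nM in this assay, likewise a limit. Among the compounds with values here, all values so far sit at the limit of > 100000 nM in this assay, at which 3 of the 3 values shown sit. Within the data shown here, the only single-point step, a step that the two limits leave unreadable from compound 1 to compound 2, is therefore unreadable. Compound 4 `CN(C)C(=O)c1sc2ncccc2c1N` differs from compound 2 by methyl in place of hydrogen on an amide-type nitrogen, methylcarbamoyl becoming dimethylcarbamoyl. Among the measured compounds shown here, no measured step has a readable size, so no change beyond the scatter is expected, a step that the limit leaves unreadable from compound 2 to compound 4. Compound 4 is expected to give 150000 nM, between 30000 nM and 1000000 nM, most probably again only a limit.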

Compound 4, half-maximal inhibitory concentration: > 100000 nM
Compound 4 was reported as a limit (the forecaster's own chance of this, stated with the estimate: 85%); the middle value does not contradict the limit.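

The steps from compound 1 and from compound 2 to compound 4 cannot be read, as each value is a limit: the limit of > 100000 nM in this assay, at which 4 of the 4 values shown sit.

The compounds shown leave open whether any change on the amide-type nitrogen gives a measured number rather than a limit.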